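The compounds below may be only part of what the source reports. "The series", "measured", "known", "first", "only" and "open" are said of these compounds alone.

Measured compounds:
- compound 1, `NCCNC(=O)c1cc2ccccc2oc1=O`: 7680 nM
- compound 2, `O=C(Nc1ccccc1Cc1ccccc1)c1cc2ccccc2oc1=O`: 910 nM

In an in vitro assay on BTI-TN-5B1-4 cells for inhibition of Amine oxidase [flavin-containing] B (Homo sapiens), read by fluorescence (a lower number here means a stronger inhibitor, a higher number a weaker inhibitor), compound 1 gives 7680 nM, the higher of the two numbers available. Compound 2, with its aryl amide, gives 910 nM in this assay, a lower number than compound 1 by a margin beyond the scatter. For the measured compounds named here, no pair that differs in a single place has been measured, so the size of any one change remains open; the two numbers only show that an aryl group on the amide nitrogen went with a lower number than a short aminoalkyl chain.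

Compound 3, `Cc1cccc(NC(=O)c2cc3ccccc3oc2=O)c1`, has not yet been measured. It differs from compound 1 in one place: 3-methylphenyl in place of 2-aminoethyl on an amide-type nitrogen. This moves the amide substituent in the same direction as in compound 2, from a chain to a ring, so a lower number in this assay is expected, likely of a size beyond the scatter. The step from compound 1 to compound 3 is expected to be a 10-fold lower number from compound 1 to compound 3 (1.01 log units; beyond the scatter). For compound 3 the estimate is 750 nM, within a range from 250 nM to 2500 nM.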

Compound 3, half-maximal inhibitory concentration: 600 nM
Compound 3: middle estimate off by 1.3-fold (0.10 log units), on the high side; measured number inside the range.
By their numbers in this assay, from the lowest: compounds 3 and 2 (each within the scatter of the next); then compound 1.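

In this assay, the series now has its first step at a single place: a 13-fold lower number from compound 1 to compound 3 (1.11 log units; beyond the scatter), with 3-methylphenyl in place of 2-aminoethyl on the amide-type nitrogen and the rest of compound 1 unchanged. The earlier numbers could only associate an aryl group on the amide nitrogen with a lower number, whereas this step ties a large change, beyond the scatter, to the substituent at this one position. No measurement available here bears on the reason for this step.

As far as these compounds go, the step combines several differences, since a six-membered aromatic ring of carbon enters while a chain carrying an amine leaves, so the share of each remains open. A plain ethyl or propyl chain on the same nitrogen would separate loss of the amine from gain of the ring, while unsubstituted phenyl would give the contribution of the methyl group, and benzyl or a longer aminoalkyl chain would test how far the change at this position extends.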